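Swapping the pyridine amide for a furan amide

The compounds below may be only part of what the source reports. "The series", "measured", "known", "first", "only" and "open" are said of these compounds alone.

Measured compounds in an assay on isolated protein for inhibition of aldehyde dehydrogenase 1A1 (Homo sapiens), read by spectrophotometry, tested at 10 uM; on this read-out lower numbers stand for less inhibition and higher numbers for more inhibition at the one concentration tested (going by the name of the read-out):
Compound 1, `Cc1cccc(Cn2c(CN3CCN(C(=O)c4cccnc4)CC3)nc3ccccc32)c1`, gives 24.5%.
Compound 2, `COc1cccc(Cn2c(CN3CCN(C(=O)C4CC4)CC3)nc3ccccc32)c1`, gives 44.4%.
Compound 3, `O=C(C1CC1)N1CCN(Cc2nc3ccccc3n2CC2CCCC2)CC1`, gives 44.5%.

Compound 1 stands lowest of the three numbers; both compound 2 and compound 3 lie above it by more than the usual scatter. Compound 2 and compound 3 differ from compound 1 in more than one place at once, so their values alone do not tell which part of the structure is responsible.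

Compound 4, `Cc1cccc(Cn2c(CN3CCN(C(=O)c4ccco4)CC3)nc3ccccc32)c1`, differs from compound 1 in one place: furan-2-yl in place of pyridin-3-yl on a carbonyl carbon. Within the data shown here, the only single-point step among the measured compounds, a number 0.1 percentage points higher from compound 2 to compound 3 (within the scatter), concerns the group on the saturated chain carbon bound to the aromatic nitrogen, not the amide, and it lies within the scatter. Among the measured compounds shown here, no measured step touches the amide side, so there is no direct guide to the size or direction of the change from compound 1 to compound 4. The expectation therefore rests on compound 1 itself, with no step beyond the scatter expected, a number 5.5 percentage points higher from compound 1 to compound 4 (within the scatter). Compound 4 is estimated at 30%, within a range from 15% to 48%.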

Compound 4, a percentage reported as inhibition, at one concentration (the size of the read-out at that concentration, not a potency): 73.2%
The estimate for compound 4 lay 43.2 percentage points below the measured number; measured number above the stated range.
By their numbers in this assay, from the lowest: compound 1; then compounds 2 and 3 (each within the scatter of the next); then compound 4.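

In this assay, the group on the carbonyl carbon proves to matter a great deal: with the rest of the molecule unchanged, furan-2-yl in place of pyridin-3-yl gives a number 48.7 percentage points higher from compound 1 to compound 4 (beyond the scatter). Among these compounds, the only earlier single-place step concerned a different part of the molecule and stayed within the scatter, whereas this is the first sign that the amide side responds strongly to change; the two groups have the same hydrogen-bond donor and acceptor counts and no net charge, differing instead in ring size and hetero atom. Nothing measured here explains the size of this step.

Still open, on these data alone, is whether ring size or the hetero atom matters more, which a thiophen-2-yl or phenyl group on the same carbonyl carbon could help separate. It is also unknown whether furan-2-yl would give a similar step with cyclopentyl on the saturated chain carbon.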